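The compounds below may be only part of what the source reports. "The series", "measured", "known", "first", "only" and "open" are said of these compounds alone.

Measured compounds:
compound 1 `CC(=O)N(C)c1ccc(Nc2nccc(-c3cccnc3)n2)cc1` gives 900 nM in a functional assay for inhibition, with Homo sapiens as the target; a higher number here means a weaker inhibitor, a lower number a stronger inhibitor;
compound 2 `CN(C)c1ccc(Nc2nccc(-c3cccnc3)n2)cc1` gives 2800 nM in this assay.

For the measured compounds named here, compound 2 holds the highest of the two numbers in this assay; its nearest neighbour is compound 1, and the only measured step, a 3.1-fold higher number from compound 1 to compound 2 (0.49 log units; beyond the scatter), separates them. Compound 3 `CN(C)c1ccc(Nc2nccc(-c3ccncc3)n2)cc1` has not yet been measured. It differs from compound 2 by pyridin-4-yl in place of pyridin-3-yl on an aromatic carbon, a rearrangement on an aromatic carbon of the shared core, next to the ring nitrogen and opposite the ring nitrogen, with the same atoms joined differently.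

Going by the values given here, no measured step bears on this change: the one step between compound 1 and compound 2 altered the substituent on the nitrogen at the other end of the molecule and left the pyridin-3-yl group untouched. There is therefore no measured basis for expecting a step in this assay in either direction beyond the scatter, and the estimate for compound 3 is anchored on compound 2 with a wide range. Compound 3 is expected to give about 4000 nM in this assay, between 1000 nM and 16000 nM, which would be an estimated step of a 1.4-fold higher number from compound 2 to compound 3 (0.15 log units; within the scatter).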

Compound 3, half-maximal inhibitory concentration: 3700 nM
The estimate for compound 3 lay 1.1-fold (0.03 log units) above the measured number; measured number inside the range.
By their numbers in this assay, from the lowest: compound 1; then compounds 2 and 3 (each within the scatter of the next).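

In this assay, for the compounds shown here, the exchange of pyridin-3-yl for pyridin-4-yl gives a 1.3-fold higher number from compound 2 to compound 3 (0.12 log units; within the scatter) and is the first measured change at this place on the shared core, so the two pyridine attachments cannot be told apart with the dimethylamino group in place. Going by these compounds alone, the earlier step, a 3.1-fold higher number from compound 1 to compound 2 (0.49 log units; beyond the scatter) at the substituted nitrogen at the other end of the molecule, lies beyond the scatter, whereas this rearrangement, with the same atoms joined differently, lies within it; of the two changes measured so far, only the one at the nitrogen separates its pair of compounds. Nothing measured here offers an explanation for this result.

The compounds shown leave open whether the place tolerates groups further from these two, such as pyridin-2-yl, plain phenyl or a saturated ring like morpholine, since both pyridines tested carry a single ring nitrogen and give numbers that cannot be separated. They also leave open whether pyridin-4-yl would match pyridin-3-yl when the acetyl group of compound 1 sits on the nitrogen at the other end.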